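The compounds below may be only part of what the source reports. "The series", "measured", "known", "first", "only" and "open" are said of these compounds alone.

The measured compounds:

Compound 1, `C/C(=C\CC/C(C)=C/CC[C@@H]1[C@@]2(C)CCC(=O)C(C)(C)[C@H]2CC[C@@]1(C)O)CC/C=C(\C)C(=O)OCc1cn(-c2ccccc2)nn1`, gives > 150000 nM in an ADME assay on L132 cells (Homo sapiens) for cytotoxicity, read by MTT assay, with a stated time of 48 h; on this read-out higher numbers stand for weaker inhibition and lower numbers for stronger inhibition; that figure is a limit of the assay, not a number.
Compound 2, `C/C(=C\CC/C(C)=C/CC[C@@H]1[C@@]2(C)CCC(=O)C(C)(C)[C@H]2CC[C@@]1(C)O)CC/C=C(\C)C(=O)OCc1cn(-c2cccc(Cl)c2)nn1`, gives 94200 nM in this assay.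
Compound 3, `C/C(=C\CC/C(C)=C/CC[C@@H]1[C@@]2(C)CCC(=O)C(C)(C)[C@H]2CC[C@@]1(C)O)CC/C=C(\C)C(=O)OCc1cn(-c2ccc(Br)cc2)nn1`, gives > 150000 nM in this assay; that figure too is a limit of the assay.

Compound 1 thus stands at the limit of this assay and has no number of its own; of the three values shown, two sit at that limit, (the limit of > 150000 nM in this assay, at which 2 of the 3 values shown sit). Compound 4, `C/C(=C\CC/C(C)=C/CC[C@@H]1[C@@]2(C)CCC(=O)C(C)(C)[C@H]2CC[C@@]1(C)O)CC/C=C(\C)C(=O)OCc1cn(-c2cccc(C)c2)nn1`, has not yet been measured. It differs from compound 1 in one place: methyl in place of hydrogen on an aromatic carbon. Two measured steps start from compound 1 and also add a single group to the same ring. With chloro in place of hydrogen the change is an at least 1.5-fold lower number from compound 1 to compound 2 (0.20 log units; that floor lies within the scatter). With bromo in place of hydrogen the change is a step that the two limits leave unreadable from compound 1 to compound 3. Neither step shows a change beyond the scatter, and the step of an at least 1.5-fold higher number from compound 2 to compound 3 (0.20 log units; that floor lies within the scatter) likewise has a floor within the scatter. The step to compound 4 is therefore expected to stay within the scatter, a number no higher from compound 1 to compound 4 (the limit leaves the size open), with a real chance that only a limit is reported again. Compound 4 is estimated at 150000 nM in this assay, expected to lie between 80000 nM and 300000 nM.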

Compound 4, half-maximal inhibitory concentration: > 150000 nM
Compound 4: only a limit was reported (the forecaster's own chance of this, stated with the estimate: 60%); the middle value lies on the limit itself.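

Methyl on the phenyl ring, meta to a large group, gives compound 4 no readable number in this assay: its > 150000 nM is a limit of the assay. Putting methyl in place of chloro gives an at least 1.5-fold higher number from compound 2 to compound 4 (0.20 log units; that floor lies within the scatter), so this pair shows no real difference between the two groups at this place, and even compound 2, the only compound here with a number, is not shown to stand apart from the limit. The steps to compound 4 from compound 1 and from compound 3 cannot be read, as both ends of each are limits, and most of the set now rests on a single ceiling: the limit of > 150000 nM in this assay, at which 3 of the 4 values shown sit.

From the compounds shown here alone, how far compound 1, compound 3 and compound 4 actually lie past that ceiling stays unknown, as a limit gives no number to compare. Also open, going by these compounds, is whether a different kind of group on the same phenyl ring, such as an amine, a carboxylic acid or a longer chain, would bring the number down by a step clearly beyond the scatter.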